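A Fluorophenyl for a Dimethylphenyl on Compound 3

The source may report more compounds than this note shows. Statements on the series, on what has been measured and on what is new or still open speak of the compounds shown alone.

compound 1 `CC(C)n1ncc2c(C(=O)Nc3ccccc3)cccc21` — 38500 nM
compound 2 `CC(C)n1ncc2c(C(=O)Nc3cccnc3)cccc21` — > 40000 nM (a limit of the assay)
compound 3 `Cc1ccc(-n2cc(CNC(=O)c3cccc4c3cnn4C(C)C)nn2)c(C)c1` — > 40000 nM (a limit of the assay)

In a functional assay on MGC-803 cells (Homo sapiens) for inhibition, read by MTT assay, with a stated time of 72 h (on this read-out lower numbers stand for stronger inhibition and higher numbers for weaker inhibition), compound 1 gives 38500 nM. For compound 2 this assay returns only a limit, > 40000 nM. For compound 3 this assay likewise returns only a limit, > 40000 nM. Compound 3 therefore stands at the limit of > 40000 nM in this assay, at which 2 of the 3 values shown sit, with no number of its own.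

Going by the values given here, the single measured step, an at least 1.0-fold higher number from compound 1 to compound 2 (0.01 log units; that floor lies within the scatter), concerns the group on the amide-type nitrogen and lies within the scatter.

Compound 4 `CC(C)n1ncc2c(C(=O)NCc3cn(-c4cccc(F)c4)nn3)cccc21` differs from compound 3 by 3-fluorophenyl in place of 2,4-dimethylphenyl on an aromatic nitrogen. Among the compounds with values here, no measured step touches this position, so the step from compound 1 to compound 2 does not bear on it, and no change beyond the scatter is expected. Compound 4 is estimated at 50000 nM, between 20000 nM and 150000 nM, which means an expected step that the limit leaves unreadable from compound 3 to compound 4.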

Compound 4, half-maximal inhibitory concentration: > 40000 nM
Compound 4 was reported as a limit; the forecaster's own chance of this, stated with the estimate: 65%; the middle value is on the limit's open side.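

Compound 3 and compound 4 both sit at a limit in this assay, so no new step can be read between them: the limit of > 40000 nM in this assay, at which 3 of the 4 values shown sit.

The compounds shown leave open whether 3-fluorophenyl in place of 2,4-dimethylphenyl on an aromatic nitrogen changes inhibition at all.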